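Diethylamide to methyl(phenyl)amide on a quinoline core

The compounds below may be only part of what the source reports. "The series", "measured", "known", "first", "only" and "open" are said of these compounds alone.

Measured compounds:
compound 1 `CCN(Cc1ccccc1)Cc1nc2ccccc2c(-c2ccccc2)c1C(=O)N(CC)CC` — 373 nM
compound 2 `CCN(Cc1ccccc1)Cc1ccccc1C(=O)N(C)c1ccccc1` — > 10000 nM
compound 3 `CCN(Cc1ccccc1)Cc1ccccc1C(=O)N(C)C` — > 10000 nM

Among the compounds with values here, in an assay on brain with Translocator protein (Rattus norvegicus) as the target (on this read-out higher numbers stand for weaker inhibition and lower numbers for stronger inhibition), compound 1 gives 373 nM, and this is the only actual number among the three measured compounds. For compound 2 the result is a limit of the assay, > 10000 nM. For compound 3 the result is likewise a limit, > 10000 nM. Compound 2 and compound 3 share a smaller core than compound 1 and differ from each other by a methyl in place of a phenyl on an amide-type nitrogen; the step from compound 2 to compound 3 is a step that the two limits leave unreadable from compound 2 to compound 3, so its size cannot be read, because both values sit at the limit of > 10000 nM in this assay, at which 2 of the 3 values shown sit.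

Compound 4 `CCN(Cc1ccccc1)Cc1nc2ccccc2c(-c2ccccc2)c1C(=O)N(C)c1ccccc1` keeps the core of compound 1 and differs from it only in the amide: methyl(phenyl)amino in place of diethylamino on a carbonyl carbon. Within the data shown here, no measured step covers this change on the core of compound 1, since the comparable exchange between compound 2 and compound 3 is hidden by the limits. The expectation therefore rests on compound 1 alone, and a weakening of modest size, near the edge of the scatter, is expected in this assay, a 2.1-fold higher number from compound 1 to compound 4 (0.33 log units; beyond the scatter). Compound 4 is estimated at 800 nM, within a range from 150 nM to 5000 nM.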

Compound 4, half-maximal inhibitory concentration: 1320 nM
For compound 4 the middle estimate is 1.7-fold (0.22 log units) below the measured one; measured number inside the range.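

The amide on the core of compound 1 can be changed without losing a readable result: in this assay, methyl(phenyl)amino in place of diethylamino on the carbonyl carbon gives a 3.5-fold higher number from compound 1 to compound 4 (0.55 log units; beyond the scatter). This is a real but modest weakening, and it shows that the larger group with its six-membered aromatic ring is accepted at this position on this core, at some cost in strength. The earlier compounds could not show this, as the same kind of amide change between compound 2 and compound 3 cannot be read, both results being limits of the assay: the limit of > 10000 nM in this assay, at which 2 of the 4 values shown sit.

The exchange also alters two things at once, with one ethyl giving way to methyl and the other to phenyl, so the compounds shown cannot say which of the two accounts for the weakening. As far as these compounds go, it also remains open how the same carbonyl carbon on this core would fare with a dipropylamino group, a longer chain than ethyl, or with a piperidine ring, in which the amide nitrogen is itself part of a ring.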